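Adding a Methyl to Compound 1 on the Sulfur-Bearing Carbon

This account rests on a few compounds, and the source may have more. Where it says the series, first, only, none or still open, it means among the compounds named here.

Measured so far, in an assay on membranes from lung (Cavia porcellus) for binding affinity to cysteinyl leukotriene receptor (Homo sapiens); a lower number here means a stronger inhibitor, a higher number a weaker inhibitor:
Compound 1, `CCCCCCCCCCCOc1ccccc1C(SCCC(=O)O)SCCC(=O)O`, gives 287 nM.
Compound 2, `O=C(O)CCSC(SCCC(=O)O)c1ccccc1OCCCCCCc1ccccc1`, gives 11500 nM.
Compound 3, `O=C(O)CCSC(SCCC(=O)O)c1ccccc1OCCCC1CCCCC1`, gives 1010 nM.

Compound 1 has the lowest number of the three and so binds most strongly. From compound 1 to compound 3 the number rises (a 3.5-fold higher number from compound 1 to compound 3 (0.55 log units; beyond the scatter)), and from compound 1 to compound 2 it rises far more (a 40-fold higher number from compound 1 to compound 2 (1.60 log units; beyond the scatter)). Within the data shown here, both steps, and the one from compound 2 to compound 3 (an 11-fold lower number from compound 2 to compound 3 (1.06 log units; beyond the scatter)), change only the chain hanging from the oxygen on the aromatic ring.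

Compound 4, `CCCCCCCCCCCOc1ccccc1C(C)(SCCC(=O)O)SCCC(=O)O`, keeps that chain exactly as in compound 1 and differs in another place: methyl in place of hydrogen on a saturated chain carbon bound to an aromatic carbon and two sulfurs. Among the measured compounds shown here, none of the measured steps touches this carbon, so nothing measured bears directly on the change. With no evidence either way, the step from compound 1 to compound 4 is expected to be small, at most modestly weakening, so a 1.6-fold higher number from compound 1 to compound 4 (0.20 log units; within the scatter) is the estimate. Compound 4 is therefore expected to give about 450 nM in this assay, within a range from 120 nM to 1700 nM.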

Compound 4, inhibition constant: > 20000 nM
Compound 4: only a limit was reported; the forecaster's own chance of this, stated with the estimate: 5%; middle value at least 44-fold (1.64 log units) from the limit.
By their numbers in this assay, from the lowest: compound 1; then compound 3; then compound 2. At a limit, above all of these: compound 4.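

The carbon bound to an aromatic carbon and two sulfurs proves highly sensitive: methyl in place of hydrogen, only 1 heavy atom, gives an at least 69-fold higher number from compound 1 to compound 4 (1.84 log units; beyond the scatter), a step on the same large scale as the biggest chain change, a 40-fold higher number from compound 1 to compound 2 (1.60 log units; beyond the scatter). Compound 1, compound 2 and compound 3 differ only in the chain on the oxygen, and each gives a measured number. Compound 4 gives only a limit, not a number: the limit of > 20000 nM in this assay, at which 1 of the 4 values shown sits.

How far compound 4 really lies from compound 1 stays unknown, and the compounds shown do not tell why this methyl has so large an effect. On these data alone, whether an ethyl group, a fluorine atom or a hydroxyl group on this carbon would give a similar result remains open, as does the effect of this methyl on compound 3.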